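Aryl amide swap from compound 2 to compound 3

The source may hold more compounds than are shown below. What is called first, only, known or untested is meant among the compounds shown, and "the series" means these compounds.

Measured compounds:
compound 1 `CC(=O)N1CCN(C(=O)N2Cc3c(NC(=O)c4ccc(F)cc4)n[nH]c3C2(C)C)CC1` — > 10000 nM
compound 2 `CN1CCC(C(=O)N2Cc3c(NC(=O)c4ccc(Cl)cc4)n[nH]c3C2(C)C)CC1` — 120 nM

For the measured compounds named here, in a functional assay on A2780 cells (Homo sapiens) for antiproliferative activity, read by fluorescence, with a stated time of 72 h (on this read-out higher numbers stand for weaker inhibition and lower numbers for stronger inhibition), compound 2 gives 120 nM, the only number in the set so far. For compound 1 this assay reports only a limit, > 10000 nM (the limit of > 10000 nM in this assay, at which 1 of the 2 values shown sits). Going by the values given here, compound 1 and compound 2 differ in more than one place, so no step can be read between them, and no step between measured compounds is available at all.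

Compound 3 `CN1CCC(C(=O)N2Cc3c(NC(=O)c4cccc(F)c4)n[nH]c3C2(C)C)CC1` differs from compound 2 by 3-fluorophenyl in place of 4-chlorophenyl on a carbonyl carbon. With no measured step of this kind in the series, the expectation rests on compound 2 alone. The expected step of a 2.1-fold higher number from compound 2 to compound 3 (0.32 log units; beyond the scatter) is a slight weakening, of a size that stays close to the usual scatter. In this assay compound 3 is expected to give 250 nM, with a range of 80 nM to 1200 nM.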

Compound 3, half-maximal inhibitory concentration: 200 nM
For compound 3 the middle estimate is 1.3-fold (0.10 log units) above the measured one; measured number inside the range.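

For the compounds shown here, the step of a 1.7-fold higher number from compound 2 to compound 3 (0.22 log units; within the scatter) in this assay is the first that can be read, and it gives the position its first direct comparison. On a carbonyl carbon whose other neighbours are an amide-type nitrogen, 3-fluorophenyl and 4-chlorophenyl cannot be told apart on this read-out, so activity at this position survives this one exchange of aryl groups. Nothing measured in the set bears on why the two groups read alike.

The exchange alters the halogen and its ring position together, so the two cannot be separated without a group such as 3-chlorophenyl. As far as these compounds go, how the position responds to an aryl group carrying an amine or a carboxylic acid stays open, and no step can be read from compound 1, which differs from compound 2 in more than one place.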